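Aryl ester variation on a shared caffeine-derived core

The source may hold more compounds than are shown below. What is called first, only, known or untested is meant among the compounds shown, and "the series" means these compounds.

Of the compounds shown here, three of one shared core have been measured in a functional assay on CCRF-CEM cells (Homo sapiens) for antiproliferative activity, read by MTT assay, with a stated time of 72 h, tested at 50 uM; a lower number here means a stronger effect, a higher number a weaker effect of the compound at the concentration tested. Compound 1 `COC(C(=O)OC(C)Cn1cnc2c1c(=O)n(C)c(=O)n2C)c1ccc(C(C)(C)C)cc1` gives 55.3% in this assay, the highest of the three numbers and therefore the weakest effect of the set. Compound 2 `CC(Cn1cnc2c1c(=O)n(C)c(=O)n2C)OC(=O)Sc1ccccc1` gives 37.1% in this assay, a number that lies below compound 1 by more than the usual scatter. Compound 3 `CC(Cn1cnc2c1c(=O)n(C)c(=O)n2C)OCc1cn(CCCn2nc3c(Br)c(Br)c(Br)c(Br)c3n2)nn1` gives 0% in this assay, the lowest number of the three, again beyond the scatter from compound 1. Going by the values given here, no two of the measured compounds differ in only one place, so no step between measured compounds is available.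

Compound 4 `COC(C(=O)OC(C)Cn1cnc2c1c(=O)n(C)c(=O)n2C)c1ccc2ccccc2c1` has not yet been measured. It differs from compound 1 in one place: naphthalen-2-yl in place of 4-(tert-butyl)phenyl on a saturated chain carbon bound to a carbonyl carbon and an oxygen on a saturated carbon. The group that leaves and the group that enters match in what is counted, and the rest of the molecule is unchanged. Among the compounds with values here, with no measured pair showing a change of this kind, the data give no step size to lean on; the expectation is a step that is small or absent, within the scatter, in either direction. The value for compound 4 in this assay is estimated at 50%, with a range from 30% to 72%. This estimate means a step of a number 5.3 percentage points lower from compound 1 to compound 4 (within the scatter) that is expected to stay within the scatter.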

Compound 4, a percentage reported as activity, at one concentration (the size of the read-out at that concentration, not a potency): 28.2%
Compound 4: middle estimate off by 21.8 percentage points, on the high side; the whole stated range lies above it.
By their numbers in this assay, from the lowest: compound 3; then compounds 4 and 2 (each within the scatter of the next); then compound 1.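

In this assay, going by these compounds alone, the exchange of 4-(tert-butyl)phenyl for naphthalen-2-yl on a saturated chain carbon bound to a carbonyl carbon and an oxygen on a saturated carbon gives the first readable step: a number 27.1 percentage points lower from compound 1 to compound 4 (beyond the scatter). This position is therefore sensitive to the aryl group it carries, even though the two groups match in heavy atoms, all of them carbon, and in hydrogen-bond donors and acceptors, leaving 2 six-membered aromatic rings against one as the counted difference. Within the data shown here, the single pair offers no measurement that accounts for the step.

Going by these compounds, it remains open whether the step follows from the second aromatic ring or from the loss of the tert-butyl group, a question that an unsubstituted phenyl or a naphthalen-1-yl group at this position would help to separate. On these data alone, it is also open whether the step holds when a hydroxyl group replaces the methoxy group shared by compound 1 and compound 4.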